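The source may hold more compounds than are shown below. What is called first, only, known or untested is meant among the compounds shown, and "the series" means these compounds.

Measured in an assay on blood for inhibition of C-X-C chemokine receptor type 3 (Homo sapiens), with a stated time of 30 min; a lower number here means a stronger inhibitor, a higher number a weaker inhibitor:
compound 1 `COCCOc1ncc(-c2nc(C(F)(F)F)sc2N2CCN(C(=O)Cn3cnc4cccnc43)[C@H](C)C2)cn1` — 182 nM
compound 2 `COc1ncc(-c2nc(C(F)(F)F)sc2N2CCN(C(=O)Cn3nc(C)nc3C)[C@H](C)C2)cn1` — 1040 nM
compound 3 `Cc1nc(C)n(CC(=O)N2CCN(c3sc(C(F)(F)F)nc3-c3cnc(OC(C)C)nc3)C[C@H]2C)n1` — 216 nM

Compound 3 gives the second highest of the three numbers; its nearest neighbour is compound 1, within the scatter, while compound 2 stands higher, beyond the scatter. Compound 4 `CCc1ncc(-c2nc(C(F)(F)F)sc2N2CCN(C(=O)Cn3nc(C)nc3C)[C@H](C)C2)cn1` differs from compound 3 by ethyl in place of isopropoxy on an aromatic carbon. Among the compounds with values here, the one measured step that bears on this place is a 4.8-fold lower number from compound 2 to compound 3 (0.68 log units; beyond the scatter), where the group on the oxygen went from methyl to isopropyl and the number fell; compound 1 sits level with compound 3. Compound 4 goes to a group of fewer heavy atoms and no acceptor, so a step back toward compound 2 is expected for compound 4, of order a 2.1-fold higher number from compound 3 to compound 4 (0.32 log units; beyond the scatter). For compound 4 the estimate in this assay is 450 nM, range 150 nM to 1400 nM.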

Compound 4, half-maximal inhibitory concentration: 567 nM
Compound 4: the middle estimate sits 1.3-fold (0.10 log units) below what was measured; the measured number falls inside the stated range.
By their numbers in this assay, from the lowest: compounds 1 and 3 (each within the scatter of the next); then compounds 4 and 2 (each within the scatter of the next).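

In this assay, on this aromatic carbon between two ring nitrogen atoms, replacing isopropoxy with ethyl gives a step beyond the scatter (a 2.6-fold higher number from compound 3 to compound 4 (0.42 log units; beyond the scatter)), so the level of compound 3 does not carry over to this smaller group without oxygen. Ethyl and methoxy cannot be separated here (a 1.8-fold lower number from compound 2 to compound 4 (0.26 log units; within the scatter)), although ethyl has no hydrogen-bond acceptor. No measurement offers an explanation for either step.

The compounds shown leave open whether the oxygen or the size of the group matters more. A propyl chain or an amine on this carbon would help separate the two.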